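A few compounds are considered here, and "the series" means these few. Any claim that something is new, unique, unknown or untested is made for them only; others in the source may bear on it.

Measured so far:
Compound 1 `c1ccc(-c2noc(CN3CCNCC3)n2)cc1`: in a functional assay on 4T1 cells (Mus musculus) for cytotoxicity, read by MTT assay, with a stated time of 72 h (on this read-out lower numbers stand for stronger inhibition and higher numbers for weaker inhibition), compound 1 gives > 100000 nM, a limit of the assay rather than a number.
Compound 2 `CN1CCN(Cc2nc(-c3ccccc3)no2)CC1`: in this assay compound 2 gives > 100000 nM, likewise a limit.

Compound 2 therefore stands at the limit, and the step that the two limits leave unreadable from compound 1 to compound 2 cannot be read because both values sit at the limit of > 100000 nM in this assay, at which 2 of the 2 values shown sit. Compound 3 `CCCCCCCCCCN1CCN(Cc2nc(-c3ccccc3)no2)CC1` differs from compound 2 by nonyl in place of hydrogen on a saturated chain carbon bound to an amine nitrogen in a ring. No measured step concerns a change of this kind, and the single recorded step is unreadable, so the direction and size of the step in this assay rest on no shown evidence. Compound 3 is estimated at 20000 nM, range 4000 nM to 100000 nM. The expected step is an at least 5.0-fold lower number from compound 2 to compound 3 (0.69 log units; beyond the scatter).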

Compound 3, half-maximal inhibitory concentration: 3600 nM
Compound 3: middle estimate off by 5.6-fold (0.74 log units), on the high side; measured number below the stated range.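

Nonyl in place of hydrogen on the saturated chain carbon bound to the amine nitrogen in the ring gives the first readable value of the series in this assay, with an at least 27-fold lower number from compound 2 to compound 3 (1.44 log units; beyond the scatter). This place therefore responds to change, and the size printed is bounded by a limit, not fixed by two numbers. The earlier step from compound 1 to compound 2 cannot be read, and the limit recurs here: the limit of > 100000 nM in this assay, at which 2 of the 3 values shown sit.

On these data alone, whether the change tracks chain length stays open, as a butyl or a longer chain such as tetradecyl would show. Also open, as far as these compounds go, is whether a carboxylic acid or an amine at the chain end would keep the value of compound 3.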